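This account rests on a few compounds, and the source may have more. Where it says the series, first, only, none or still open, it means among the compounds named here.

Three members of the series have a reading in an ADME assay (liver) for metabolic stability, with Liver microsome (Rattus norvegicus) as the target, using microsomes and NADPH, with a stated time of 30 min; on this read-out higher numbers stand for fast clearance and lower numbers for slow clearance. Compound 1 `CC#CCC(O)(c1ccc(N2CCN(S(=O)(=O)c3ccc(N)nc3)C[C@@H]2C#CC)cc1)C(F)(F)F` gives 115 mL.min-1.g-1, the highest of the three numbers. Compound 2 `CC#C[C@H]1CN(S(=O)(=O)c2ccc(N)nc2)CCN1c1ncc(C(O)(C(F)(F)F)C(F)(F)F)s1`, built on a different core and carrying a different substituent, gives 34 mL.min-1.g-1 in this assay, and compound 3 `CC#C[C@H]1CN(S(=O)(=O)c2ccc(N)nc2)CCN1c1ncc(C(O)(C(F)(F)F)C(F)(F)F)cn1` gives 28 mL.min-1.g-1. Compound 1 therefore stands beyond the scatter above both of them, nearest to compound 2 and furthest from compound 3. Going by the values given here, none of the three measured compounds differs from another in a single place, so no one-point step within the measured set is available.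

Compound 4 `CC#C[C@H]1CN(S(=O)(=O)c2ccc(N)nc2)CCN1c1ccc(C(C)=O)cc1` has not yet been run in this assay. It differs from compound 1 in one place: a group of 3 heavy atoms (2 carbon, 1 oxygen; no ring) in place of a group of 10 heavy atoms (6 carbon, 1 oxygen, 3 fluorine; no ring), on an aromatic carbon. Among the compounds with values here, no measured pair tracks this particular exchange. Within the data shown here, the only orientation comes from compound 2 at 34 mL.min-1.g-1 and compound 3 at 28 mL.min-1.g-1, both lacking the larger group of compound 1 and both sitting well below it, although each also differs from compound 1 in its core. On that basis the step of a 2.6-fold lower number from compound 1 to compound 4 (0.41 log units; beyond the scatter) is expected to run downward and to exceed the scatter. Compound 4 is estimated to give 45 mL.min-1.g-1, with a range from 20 mL.min-1.g-1 to 110 mL.min-1.g-1.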

Compound 4, intrinsic clearance in microsomes: 249 mL.min-1.g-1
Beside the measured number, compound 4's estimate is 5.5-fold (0.74 log units) below it; the measured number lies above the stated range.
By their numbers in this assay, from the lowest: compounds 3 and 2 (each within the scatter of the next); then compound 1; then compound 4.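

In this assay, going by these compounds alone, the exchange on this aromatic carbon, para to a large group, gives the first one-place step: a 2.2-fold higher number from compound 1 to compound 4 (0.34 log units; beyond the scatter). The step lies beyond the scatter and shows that this position affects the read-out on the shared core, with acetyl, the group of 3 heavy atoms, reading higher than the group of 10 heavy atoms it replaces. No measurement at hand bears on the reason for this step.

A single exchange cannot separate the parts of the departing group, since its hydroxyl, its fluorine atoms and its triple bond all leave together with the change in size, and acetyl brings its own carbonyl. Going by these compounds, it remains open how the read-out responds here to other groups on the same aromatic carbon, such as a nitrile, a carboxylic acid, a primary amide or a simple tertiary alcohol without fluorine, and whether the direction of this step would hold on the cores of the other compounds.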